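The compounds below may be only part of what the source reports. "The series", "measured", "known", "first", "only" and "open" are said of these compounds alone.

Of the compounds shown here, three have been tested so far, and all three sit at the upper limit of the assay. Compound 1 `CCN(CC)S(=O)(=O)c1ccc(S(=O)(=O)N2CCC[C@@H](C(=O)NC3CN(C(=O)C4CC4)C3)C2)cc1` in a functional assay on MIA PaCa-2 cells (Homo sapiens) for inhibition, read by MTT assay, with a stated time of 3 days (a higher number here means a weaker inhibitor, a lower number a stronger inhibitor), gives > 10000 nM, which is a limit of the assay rather than a measured number. Compound 2 `CCOC(=O)[C@@H]1CCCN(S(=O)(=O)c2ccc(S(=N)(=O)N(CC)CC)cc2)C1` in this assay also gives only a limit, > 10000 nM. Compound 3 `CCOC(=O)[C@@H]1CCCN(C(=O)c2ccc(S(=O)(=O)N(CC)CC)cc2)C1` in this assay likewise gives a limit, > 10000 nM. This is summed up by the limit of > 10000 nM in this assay, at which 3 of the 3 values shown sit, so compound 1 stands level with the other two and no ranking among them can be drawn.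

The next compound, compound 4 `CCN1CC(NC(=O)[C@@H]2CCCN(S(=O)(=O)c3ccc(S(=O)(=O)N(CC)CC)cc3)C2)C1`, is built from compound 1 by a single change: ethyl in place of cyclopropylcarbonyl on an amine nitrogen in a ring. Cut one bond further out, the change reads 1-(cyclopropylcarbonyl)azetidin-3-yl to 1-ethylazetidin-3-yl. Among the measured compounds shown here, no pair of measured compounds differing in one place exists here, so there is no measured step to lean on. With every value shown resting at the limit, the expectation for compound 4 is a value again beyond the limit, a step that the limit leaves unreadable from compound 1 to compound 4, nothing beyond the usual scatter. The expected value for compound 4 is 15000 nM, with a range from 5000 nM to 50000 nM.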

Compound 4, half-maximal inhibitory concentration: > 10000 nM
Compound 4: no number, only a limit; the forecaster's own chance of this, stated with the estimate: 75%; the middle value is on the limit's open side.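

Among the compounds shown here, compound 4 gives only a limit, as compound 1 does, so no step between compound 1 and compound 4 can be read: the limit of > 10000 nM in this assay, at which 4 of the 4 values shown sit. The compounds shown leave open which change to the shared core, if any, would give an actual number in this assay.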